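Swapping the aryl group on the anilino nitrogen

The source may report more compounds than this note shows. Statements on the series, on what has been measured and on what is new or still open speak of the compounds shown alone.

Compound 1 `CCc1ccc(NC2=CC(=O)c3nc4n(c3C2=O)[C@H]2OC[C@@H](O)[C@H]2OC4)cc1`: 3990 nM
Compound 2 `O=C1C(N2CCCC2)=CC(=O)c2c1nc1n2[C@H]2OC[C@@H](O)[C@H]2OC1`: > 16000 nM

In a functional assay on HeLa cells (Homo sapiens) for inhibition, read by sulforhodamine B assay (on this read-out lower numbers stand for stronger inhibition and higher numbers for weaker inhibition), compound 1 gives 3990 nM, the only number shown. Compound 2 reaches only a limit, (the limit of > 16000 nM in this assay, at which 1 of the 2 values shown sits). Among the measured compounds shown here, no step between two measured compounds is available. Compound 3 `O=C1C=C(Nc2cccc(Cl)c2)C(=O)c2c1nc1n2[C@H]2OC[C@@H](O)[C@H]2OC1` differs from compound 1 by 3-chlorophenyl in place of 4-ethylphenyl on an amine nitrogen. For the measured compounds named here, with no measured step to lean on, the expected step of a 1.3-fold higher number from compound 1 to compound 3 (0.10 log units; within the scatter) is placed within the usual scatter, in no firm direction. Compound 3 is therefore estimated at 5000 nM in this assay, with a range from 1500 nM to 16000 nM.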

Compound 3, half-maximal inhibitory concentration: 6040 nM
Compound 3: middle estimate off by 1.2-fold (0.08 log units), on the low side; the measured number falls inside the stated range.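

Exchanging 4-ethylphenyl for 3-chlorophenyl on the amine nitrogen gives, in this assay, a 1.5-fold higher number from compound 1 to compound 3 (0.18 log units; within the scatter), so these two aryl groups cannot be told apart on this read-out. The two groups differ in both substituent and ring position, so neither change can be judged alone. Nothing measured here speaks to a cause for this step. From the compounds shown here alone, it remains open whether a benzyl group, a pyridine ring or a carboxylic acid on the aryl ring would move the number beyond the scatter.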